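Thioether side-chain variation on the shared core

The compounds below may be only part of what the source reports. "The series", "measured", "known", "first", "only" and "open" are said of these compounds alone.

Measured so far in a functional assay on MCF7 cells (Homo sapiens) for inhibition, read by MTT assay, with a stated time of 72 h; a lower number here means a stronger inhibitor, a higher number a weaker inhibitor:
compound 1, `Cc1cc(Nc2cc(-c3ccccc3)[nH]n2)n2nc(SCCc3ccccc3)nc2n1`, 2700 nM
compound 2, `Cc1cc(Nc2cc(-c3ccccc3)[nH]n2)n2nc(SCc3ccc(C(F)(F)F)cc3)nc2n1`, 4820 nM

Among the compounds with values here, compound 2 holds the higher of the two numbers, but the single step of a 1.8-fold higher number from compound 1 to compound 2 (0.25 log units; within the scatter) sits within the scatter, so the two compounds cannot be ordered.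

Compound 3, `Cc1cc(Nc2cc(-c3ccccc3)[nH]n2)n2nc(SCC3CC3)nc2n1`, changes the same side chain: cyclopropyl in place of 4-(trifluoromethyl)phenyl on a saturated chain carbon bound to a sulfur. Within the data shown here, the only step that bears on this position is a 1.8-fold higher number from compound 1 to compound 2 (0.25 log units; within the scatter), and it did not rise above the scatter. No larger movement is therefore expected from compound 2 to compound 3 in this assay; the step of a 1.4-fold lower number from compound 2 to compound 3 (0.14 log units; within the scatter) is the estimate. For compound 3 the expected value is 3500 nM, with a range from 1200 nM to 10000 nM.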

Compound 3, half-maximal inhibitory concentration: > 50000 nM
Compound 3: only a limit was reported; the forecaster's own chance of this, stated with the estimate: 5%; middle value at least 14-fold (1.15 log units) from the limit.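

In this assay this side chain position is not as flat as the earlier pair suggested: cyclopropyl gives an at least 10-fold higher number from compound 2 to compound 3 (1.01 log units; beyond the scatter) and an at least 18-fold higher number from compound 1 to compound 3 (1.26 log units; beyond the scatter). Among these compounds, the two side chains carrying a six-membered aromatic ring stay within the scatter of each other, while the one carrying cyclopropyl falls well away from both. Compound 3 stands at a limit of the assay, not at a number: the limit of > 50000 nM in this assay, at which 1 of the 3 values shown sits.

On these data alone, whether the aromatic ring or the ring size matters remains open. A cyclohexyl group in the same place could separate the two, while an amine there would test tolerance further.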